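This account rests on a few compounds, and the source may have more. Where it says the series, first, only, none or still open, it means among the compounds named here.

Compound 3 `CCCCCCCCN(C)C(=O)Cn1cc(Cc2cnc(O)nc2)c(=O)nc1SCc1ccc(F)cc1` stands highest of the three compounds measured in a functional assay on a cell-free system (plasma, Oryctolagus cuniculus) for inhibition of platelet-activating factor acetylhydrolase (Homo sapiens), tested at 100 nM; on this read-out lower numbers stand for less inhibition and higher numbers for more inhibition at the one concentration tested (going by the name of the read-out): in this assay compound 3 gives 34%, whereas compound 1 `CCCCCCCCN(C)C(=O)Cn1cc(Cc2cnc(OCC)nc2)c(=O)nc1SCc1ccc(F)cc1` gives 7% and compound 2 `CCCCCCCCN(C)C(=O)Cn1cc(Cc2cnc(OCc3ccccc3)nc2)c(=O)nc1SCc1ccc(F)cc1` gives 8% in this assay.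

Compound 4 `CCCCCCCCN(C)C(=O)Cn1cc(Cc2cnc(=O)n(CC)c2)c(=O)nc1SCc1ccc(F)cc1` differs from compound 3 by a group of 9 heavy atoms (6 carbon, 2 nitrogen, 1 oxygen; one six-membered aromatic ring with 2 hetero atoms) in place of a group of 7 heavy atoms (4 carbon, 2 nitrogen, 1 oxygen; one six-membered aromatic ring with 2 hetero atoms), on a saturated chain carbon bound to an aromatic carbon.

Among the compounds with values here, the steps that bear on this change are the two that uncover the hydrogen-bond donor: a number 27 percentage points higher from compound 1 to compound 3 (beyond the scatter) and a number 26 percentage points higher from compound 2 to compound 3 (beyond the scatter). Both capped forms sit at the low end, and a number 1 percentage points higher from compound 1 to compound 2 (within the scatter) shows that the size of the cap made no difference. Compound 4 again has no hydrogen-bond donor, so the account expects it to fall back toward the level of compound 1 and compound 2, with a step of about a number 22 percentage points lower from compound 3 to compound 4 (beyond the scatter) downward in this assay.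

The estimate for compound 4 in this assay is therefore 12%, expected to lie between 3% and 30%.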

Compound 4, a percentage reported as inhibition, at one concentration (the size of the read-out at that concentration, not a potency): 5%
Estimate against measurement, compound 4: 7 percentage points above; low and high end bracket the measured number.
By their numbers in this assay, from the lowest: compounds 4, 1 and 2 (each within the scatter of the next); then compound 3.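

The step of a number 29 percentage points lower from compound 3 to compound 4 (beyond the scatter) shows that, in this assay, the number also drops when the ethyl group is placed elsewhere on the group rather than on the oxygen on the aromatic ring. The step of a number 2 percentage points lower from compound 1 to compound 4 (within the scatter) shows that the two ethyl-bearing groups, equal in heavy atoms, cannot be told apart here, so among the compounds shown only the 2-hydroxypyrimidin-5-yl group of compound 3 stands out, and none of the other compounds goes against this. No measurement on hand explains the drop.

Going by these compounds, what stays open is whether an amine or a carboxylic acid in place of the hydroxy group would keep the higher number. A single concentration also leaves the potencies of these compounds unresolved, and the low numbers cannot separate the missing hydrogen-bond donor from the added ethyl group.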